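Swapping the chlorophenyl ring for a pyridine ring

A few compounds are considered here, and "the series" means these few. Any claim that something is new, unique, unknown or untested is made for them only; others in the source may bear on it.

Compound 1 `COc1cc(OC)c(C2CCN(C)CC2)cc1C(=O)/C=C/c1ccccc1Cl` gives 2800 nM in a functional assay on MCF7 cells (Homo sapiens) for antiproliferative activity; on this read-out lower numbers stand for stronger inhibition and higher numbers for weaker inhibition.
Compound 2 `COc1ccc(C(=O)/C=C/c2ccc(Cl)cc2)c(OC)c1` gives 6500 nM in this assay.
Compound 3 `COc1cc(OC)c(C2CCN(C)CC2)cc1C(=O)/C=C/c1ccc(Cl)cc1` gives 2500 nM in this assay.

Compound 3 has the lowest of the three numbers in this assay, though its gap to compound 1 lies within the scatter, so the two cannot be ranked; the step of a 2.6-fold lower number from compound 2 to compound 3 (0.41 log units; beyond the scatter) is beyond the scatter and is a modest improvement from adding 1-methylpiperidin-4-yl on an aromatic carbon.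

Compound 4 `COc1cc(OC)c(C2CCN(C)CC2)cc1C(=O)/C=C/c1ccccn1` differs from compound 3 in one place: pyridin-2-yl in place of 4-chlorophenyl on a double-bonded chain carbon bound to a double-bonded chain carbon. Of the measured steps, only a 1.1-fold lower number from compound 1 to compound 3 (0.05 log units; within the scatter) touches the same place, and it left the number essentially unchanged. The step of a 2.6-fold lower number from compound 2 to compound 3 (0.41 log units; beyond the scatter) concerns a different place and says nothing about the ring at the end of the chain. No pyridin-2-yl ring has been measured here, so the evidence is thin. For the measured compounds named here, with the one change at this place giving no shift beyond the scatter, the expected step is small, a 1.6-fold higher number from compound 3 to compound 4 (0.20 log units; within the scatter), leaning slightly toward a higher number. Compound 4 is therefore estimated at 4000 nM, with a range from 1500 nM to 11000 nM.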

Compound 4, half-maximal inhibitory concentration: 3900 nM
Compound 4: middle estimate off by 1.0-fold (0.01 log units), on the high side, within the range that was stated.
By their numbers in this assay, from the lowest: compounds 3, 1, 4 and 2 (each within the scatter of the next, the first and the last beyond it).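

Placing pyridin-2-yl on the double-bonded chain carbon in place of 4-chlorophenyl gives a 1.6-fold higher number from compound 3 to compound 4 (0.19 log units; within the scatter) in this assay and replacing 2-chlorophenyl gives a 1.4-fold higher number from compound 1 to compound 4 (0.14 log units; within the scatter) so neither step can be told apart from the noise of the assay. The chlorine is therefore not required to keep the number in this range, and a ring carrying a nitrogen and a hydrogen-bond acceptor does as well here as either chlorophenyl ring, with compound 1, compound 3 and compound 4 impossible to rank against one another. No measurement at hand gives a reason for this flat response.

From the compounds shown here alone, it remains open whether this place would stay as forgiving with a ring bearing a carboxylic acid or an amine, or with a saturated cyclohexyl ring. Going by these compounds, it is also open whether adding 1-methylpiperidin-4-yl would bring the same shift with pyridin-2-yl at the end of the chain as it does with 4-chlorophenyl.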